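The source may hold more compounds than are shown below. What is called first, only, known or untested is meant among the compounds shown, and "the series" means these compounds.

In an ADME assay on Vero cells (Chlorocebus sabaeus) for cytotoxicity, read by MTT assay, with a stated time of 72 h (on this read-out lower numbers stand for higher toxicity in this test and higher numbers for lower toxicity in this test), the three measured compounds read as follows:

compound 1, `COc1ccc(/C=C/C(=O)NCCNc2ccnc3cc(Cl)ccc23)cc1OC`, gives 5600 nM;
compound 2, `COc1cc(OC)c(OC)cc1/C=C/C(=O)NCCNc1ccnc2cc(Cl)ccc12`, gives 16100 nM;
compound 3, `COc1ccc(/C=C/C(=O)c2ccc(OCC(O)CNCCNc3ccnc4cc(Cl)ccc34)cc2)cc1OC`, gives 10200 nM.

Compound 2 differs from compound 1 by methoxy in place of hydrogen on an aromatic carbon, and that change made a 2.9-fold higher number from compound 1 to compound 2 (0.46 log units; beyond the scatter). The difference between the cores of compound 1 and compound 3 is not broken down here. Compound 4, `COc1cc(/C=C/C(=O)c2ccc(OCC(O)CNCCNc3ccnc4cc(Cl)ccc34)cc2)cc(OC)c1OC`, is not yet measured; it differs from compound 3 by methoxy in place of hydrogen on an aromatic carbon. The incoming group is the same, but its surroundings are not: in compound 2 it stands ortho to a large group, meta to a methoxy group and para to a methoxy group, whereas in compound 4 it stands ortho to a methoxy group, meta to a large group and meta to a methoxy group, so this is the same kind of change, not the same. Set beside a 2.9-fold higher number from compound 1 to compound 2 (0.46 log units; beyond the scatter), the step expected for compound 4 in this assay is a 2.0-fold higher number from compound 3 to compound 4 (0.29 log units; within the scatter), resting on that single earlier step, so compound 4 is estimated at 20000 nM, within 9000 nM to 45000 nM.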

Compound 4, half-maximal cytotoxic concentration: 1910 nM
Compound 4: the middle estimate sits 10-fold (1.02 log units) above what was measured; measured number below the stated range.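

In this assay, adding the methoxy group gave a 5.3-fold lower number from compound 3 to compound 4 (0.73 log units; beyond the scatter), so the number fell where the same kind of change had earlier raised it, and the two steps disagree: the same change on two cores in this assay, a 2.9-fold higher number (0.46 log units; beyond the scatter) from compound 1 to compound 2 and a 5.3-fold lower number (0.73 log units; beyond the scatter) from compound 3 to compound 4, 15-fold (1.19 log units) apart, beyond the scatter of two such steps. In this series, then, the step seen on one core cannot simply be carried to the other, not even in its direction. Among these compounds, the comparison does not show what sets the two steps apart, as the cores differ, the incoming group has different surroundings, and each core offers only one step.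

The compounds shown leave open whether an ethoxy group or a fluorine atom entering at the same place on the core of compound 3 would also lower the number.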